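A few compounds are considered here, and "the series" means these few. Any claim that something is new, unique, unknown or untested is made for them only; others in the source may bear on it.

Working notes on the acylguanidine series. Compound 1 `Cc1nc(N)sc1CCCN/C(N)=N/C(=O)N[C@H](C)c1ccccc1` gives 7.59 nM in a functional assay on Right cardiac atrium for agonist activity at histamine H2 receptor (Cavia porcellus), with a stated time of 30 min, in the presence of a further agent that is not named here; on this read-out lower numbers stand for an effect already at smaller amounts and higher numbers for an effect only at larger amounts of compound; compound 2 `Cc1nc(N)sc1CCCN/C(N)=N/C(=O)N[C@@H](C)c1ccccc1` gives 23.4 nM. The step of a 3.1-fold higher number from compound 1 to compound 2 (0.49 log units; beyond the scatter) rests only on (the fact that compounds 1 and 2 differ only in the configuration as drawn), and compound 2 therefore stands as the higher of the two numbers. Compound 3 `Cc1nc(N)sc1CCCN/C(N)=N/C(=O)NCc1ccco1` carries (furan-2-yl)methyl in place of 1-phenylethyl on an amide-type nitrogen, a change that removes the stereocentre altogether rather than inverting it, so the measured step bears on it only loosely. A modest step in either direction is expected, so compound 3 is estimated at 15 nM (range 4 nM to 60 nM), meaning an expected step of a 1.6-fold lower number from compound 2 to compound 3 (0.19 log units; within the scatter).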

Compound 3, half-maximal effective concentration: 11.8 nM
Estimate against measurement, compound 3: 1.3-fold (0.10 log units) above; measured number inside the range.
By their numbers in this assay, from the lowest: compounds 1, 3 and 2 (each within the scatter of the next, the first and the last beyond it).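

On this position, in this assay, (furan-2-yl)methyl in place of 1-phenylethyl on the amide-type nitrogen stays within the scatter of both configurations: a 2.0-fold lower number from compound 2 to compound 3 (0.30 log units; within the scatter) and a 1.6-fold higher number from compound 1 to compound 3 (0.19 log units; within the scatter). A defined stereocentre and a six-membered aromatic ring of carbon are therefore not required here for a number in this range. The stereocentre still separates the two 1-phenylethyl compounds, and that gap has a single structural origin: the fact that compounds 1 and 2 differ only in the configuration as drawn.

On these data alone, the furan ring and the loss of the methyl branch enter together, so their separate contributions remain open. A benzyl group on the same nitrogen would separate them.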